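Chloro to Methoxy: Expecting the Next Number

A few compounds are considered here, and "the series" means these few. Any claim that something is new, unique, unknown or untested is made for them only; others in the source may bear on it.

Three measured compounds share one core. Compound 1 `Cc1cccc(-c2n[nH]cc2N2CCCNCC2)c1`, compound 2 `Clc1ccc(-c2n[nH]cc2N2CCCNCC2)cc1` and compound 3 `COc1ccccc1-c1n[nH]cc1N1CCCNCC1` were each tested in an assay on isolated protein for binding affinity to 5-hydroxytryptamine receptor 1D (Homo sapiens); a lower number here means a stronger inhibitor, a higher number a weaker inhibitor. Compound 2 gives 1230 nM, the lowest of the two numbers reported. Compound 1 gives 3290 nM, a gap beyond the usual scatter. For compound 3 only a limit of > 10000 nM is reported, not a number. Compound 4 `COc1ccc(-c2n[nH]cc2N2CCCNCC2)cc1` has not yet been measured. It differs from compound 2 by methoxy in place of chloro on an aromatic carbon, a methoxy in place of chloro on an aromatic carbon. Going by the values given here, no measured pair shows this exact change, so the size of the step in this assay is uncertain; a move toward weaker binding beyond the scatter is expected. Compound 4 is therefore estimated at 4000 nM, with a range from 1500 nM to 12000 nM, meaning an expected step of a 3.3-fold higher number from compound 2 to compound 4 (0.51 log units; beyond the scatter).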

Compound 4, inhibition constant: 3030 nM
Compound 4: the middle estimate sits 1.3-fold (0.12 log units) above what was measured; the range from low to high includes it.
By their numbers in this assay, from the lowest: compound 2; then compounds 4 and 1 (each within the scatter of the next). At a limit, above all of these: compound 3.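

Going by these compounds alone, this is the first measured swap at this position, on an aromatic carbon para to a large group. In this assay, methoxy in place of chloro gives a 2.5-fold higher number from compound 2 to compound 4 (0.39 log units; beyond the scatter), a modest weakening rather than a complete loss of binding. Compound 4 still returns a real number and not a limit, so the size of this step can be read: the limit of > 10000 nM in this assay, at which 1 of the 4 values shown sits.

On these data alone, whether the weakening follows from losing the chlorine or from adding the oxygen stays open. An amine or a carboxylic acid at this same position would show how widely the group here can vary.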